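Methyl for amino on the thiazole of compound 2

The source may report more compounds than this note shows. Statements on the series, on what has been measured and on what is new or still open speak of the compounds shown alone.

Measured so far:
compound 1 `CCCCNc1nc(N)nc2c1CN(C(=O)c1cnccn1)CC2` — 2.2 uM
compound 2 `CCCCNc1nc(N)nc2c1CN(C(=O)c1csc(N)n1)CC2` — 6.9 uM

Within the data shown here, in an assay on HEK293 cells for agonist activity at Toll-like receptor 8 (Homo sapiens), read by a luciferase reporter, with a stated time of 6 h (on this read-out higher numbers stand for an effect only at larger amounts of compound and lower numbers for an effect already at smaller amounts), compound 2 stands at the highest of the two numbers; its nearest neighbour is compound 1, and the only measured step is a 3.1-fold higher number from compound 1 to compound 2 (0.50 log units; beyond the scatter). The step followed here is from compound 2 to compound 3 `CCCCNc1nc(N)nc2c1CN(C(=O)c1csc(C)n1)CC2`: methyl in place of amino on an aromatic carbon. Among the measured compounds shown here, no measured step touches this change: the one step available exchanges the whole ring attached to the carbonyl, not a substituent on the 2-amino-1,3-thiazol-4-yl group, so it gives no direct guide to the direction. On that basis compound 3 is expected to stay close to compound 2, with a step of a 1.2-fold lower number from compound 2 to compound 3 (0.06 log units; within the scatter) that is not expected to lie beyond the scatter, and the estimate for compound 3 in this assay is 6 uM, within a range from 2 uM to 18 uM.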

Compound 3, minimum effective concentration: 1.8 uM
For compound 3 the middle estimate is 3.3-fold (0.52 log units) above the measured one, outside the stated range (below it).
By their numbers in this assay, from the lowest: compounds 3 and 1 (each within the scatter of the next); then compound 2.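

Compound 2 and compound 3 differ by a single group on the thiazole, on the aromatic carbon next to the ring nitrogen and the ring sulfur, and in this assay that change alone gives a 3.8-fold lower number from compound 2 to compound 3 (0.58 log units; beyond the scatter) and shows that this position affects the read-out. The step of a 1.2-fold lower number from compound 1 to compound 3 (0.09 log units; within the scatter) also shows that the 2-methyl-1,3-thiazol-4-yl group and the pyrazin-2-yl group cannot be told apart here, so the higher number seen for compound 2 is not shared by every thiazole amide. No measurement available here accounts for the difference between amino and methyl.

From the compounds shown here alone, how an ethyl group, a chlorine or a dimethylamino group on the same carbon would read remains open. So does whether amino and methyl differ in the same way when a longer chain replaces the butyl chain on the core.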